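Benzyl for Propyl on the Sulfur of an Inactive Series

A few compounds are considered here, and "the series" means these few. Any claim that something is new, unique, unknown or untested is made for them only; others in the source may bear on it.

Measured so far:
- compound 1, `CCCSc1nc(N/N=C(\C)c2ccccc2O)c2nnn(Cc3ccccc3Cl)c2n1`: > 64000 nM
- compound 2, `CCCSc1nc(N/N=C/c2cc(OC)c(OC)c(OC)c2)c2nnn(Cc3ccccc3)c2n1`: > 64000 nM
- compound 3, `C#CCSc1nc(N/N=C/c2ccc(N(C)C)cc2)c2nnn(Cc3ccccc3)c2n1`: > 64000 nM

Of the compounds shown here, three have been tested in a functional assay on MCF7 cells (Homo sapiens) for antiproliferative activity, read by MTT assay, with a stated time of 72 h; on this read-out lower numbers stand for stronger inhibition and higher numbers for weaker inhibition. For compound 1 the value > 64000 nM is a limit of the assay, not a number. For compound 2 the value > 64000 nM is likewise a limit. For compound 3 the value > 64000 nM is also a limit. Compound 2 therefore stands where every measured compound stands, at the limit of > 64000 nM in this assay, at which 3 of the 3 values shown sit, so nothing orders these three against one another.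

Compound 4, `COc1cc(/C=N/Nc2nc(SCc3ccccc3)nc3c2nnn3Cc2ccccc2)cc(OC)c1OC`, has not been measured. It differs from compound 2 in one place: phenyl in place of ethyl on a saturated chain carbon bound to a sulfur, which reads, cut one bond further out, as propylsulfanyl to benzylsulfanyl. Within the data shown here, no measured pair shows what this change does, so the size and direction of the step in this assay are unknown. Compound 4 is expected to give 64000 nM, within 20000 nM to 200000 nM, a step of a number no higher from compound 2 to compound 4 (the limit leaves the size open), that is, no change beyond the scatter, with a limit again the most likely outcome.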

Compound 4, half-maximal inhibitory concentration: 13500 nM
Estimate against measurement, compound 4: 4.7-fold (0.68 log units) above, and the stated range ends above it.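

Replacing propylsulfanyl with benzylsulfanyl gives, in this assay, an at least 4.7-fold lower number from compound 2 to compound 4 (0.67 log units; beyond the scatter), so this group on the sulfur is a place where one change can move the read-out. Among these compounds, compound 4 is also the first compound here with a measured number, which gives later changes a value to be compared against. The true size of the step stays open, and compound 4 stands alone in having a number: the limit of > 64000 nM in this assay, at which 3 of the 4 values shown sit.

A cyclohexylmethyl group or a longer chain such as pentyl on the sulfur would help show whether the aromatic ring matters or whether added carbon alone is enough. As far as these compounds go, it also remains open whether benzylsulfanyl gives a similar step when a ring carrying a dimethylamino group replaces the trimethoxyphenyl ring of compound 4.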